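The compounds below may be only part of what the source reports. "The series", "measured", "known", "first", "only" and "open" are said of these compounds alone.

The measured compounds:

Compound 1 `NC(=S)c1c(N)n(COCc2ccccc2)c2ncnc(N)c12` gives 225000 nM in a functional assay on KB cells (Homo sapiens) for inhibition; on this read-out higher numbers stand for weaker inhibition and lower numbers for stronger inhibition.
Compound 2 `N#Cc1c(N)n(COCc2ccccc2)c2ncnc(N)c12` gives 118000 nM in this assay.
Compound 3 `COCCOCn1cc(C#N)c2c(N)ncnc21` reaches only a limit of this assay, reported as > 100000 nM.

Compound 1 and compound 2 share a core and differ in one place: a group of 3 heavy atoms (1 carbon, 1 nitrogen, 1 sulfur; no ring) in place of a group of 2 heavy atoms (1 carbon, 1 nitrogen; no ring), on an aromatic carbon. The step that goes with this change is a 1.9-fold higher number from compound 2 to compound 1 (0.28 log units; within the scatter), so the two values are not separated by more than the ordinary variation of repeated measurements, and no order between them is claimed.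

Compound 3 carries a different core; how the two cores differ is not broken down here. For compound 3 the assay gives a limit, as noted in the limit of > 100000 nM in this assay, at which 1 of the 3 values shown sits.

The unmeasured compound 4 `COCCOCn1cc(C(N)=S)c2c(N)ncnc21` is built from compound 3 by the same kind of change: a group of 3 heavy atoms (1 carbon, 1 nitrogen, 1 sulfur; no ring) in place of a group of 2 heavy atoms (1 carbon, 1 nitrogen; no ring), on an aromatic carbon. The surroundings of the place are not the same word for word, since in the earlier pair the change sits next to the ring atom that bears an amino group, whereas here it sits two ring bonds from the ring atom that bears a (2-methoxyethoxy)methyl group.

Compound 4 is expected to show a step that the limit leaves unreadable from compound 3 to compound 4, resting on the step of a 1.9-fold higher number from compound 2 to compound 1 (0.28 log units; within the scatter) and on the limit of compound 3 given as > 100000 nM. Compound 4 is therefore estimated at 200000 nM, with a range from 100000 nM to 500000 nM, and it is likely that only a limit is reported.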

Compound 4, half-maximal inhibitory concentration: 183000 nM
Compound 4: middle estimate off by 1.1-fold (0.04 log units), on the high side; the measured number falls inside the stated range.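

No step from compound 3 to compound 4 can be read in this assay, because compound 3 is known only as a limit: the limit of > 100000 nM in this assay, at which 1 of the 4 values shown sits.

The compounds shown leave open whether replacing the cyano group with the sulfur-bearing group changes the read-out at all on the core of compound 3, since the only readable instance of this change, on the core of compound 1, stays within the scatter.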